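Diaryl ureas with a thiazole or imidazole tail on breast cancer cells

The compounds below may be only part of what the source reports. "The series", "measured", "known", "first", "only" and "open" are said of these compounds alone.

Measured compounds:
Compound 1 `Cc1ccc(NC(=O)Nc2ccc(Oc3ccc(-c4nccs4)cc3)cc2)cc1` gives 22.8%.
Compound 2 `O=C(Nc1ccc(Oc2ccc(-c3nccs3)cc2)cc1)Nc1cc(C(F)(F)F)ccc1Cl` gives 60.4%.
Compound 3 `Cc1ccc(NC(=O)Nc2ccc(Oc3ccc(-c4ncc[nH]4)cc3)cc2)cc1` gives 49.3%.

All three were tested in a functional assay on MDA-MB-231 cells (Homo sapiens) for inhibition, read by MTT assay and WST assay, with a stated time of 72 h, tested at 10 uM; a lower number here means less inhibition of growth, a higher number more inhibition of growth at the concentration tested. Two single changes to compound 1 have been measured. The first, (2-chloro-5-(trifluoromethyl)phenyl in place of 4-methylphenyl on an amide-type nitrogen), produced the step of a number 37.6 percentage points higher from compound 1 to compound 2 (beyond the scatter). The second, (1H-imidazol-2-yl in place of 1,3-thiazol-2-yl on an aromatic carbon), produced the step of a number 26.5 percentage points higher from compound 1 to compound 3 (beyond the scatter). Compound 3 thus stands second of the three, with compound 2 above it.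

Compound 4 `O=C(Nc1ccc(Oc2ccc(-c3ncc[nH]3)cc2)cc1)Nc1cc(C(F)(F)F)ccc1Cl` is not yet measured. It differs from compound 3 by 2-chloro-5-(trifluoromethyl)phenyl in place of 4-methylphenyl on an amide-type nitrogen, which is the same change already seen from compound 1 to compound 2, made at a place described in the same words. The two cores differ by 1H-imidazol-2-yl in place of 1,3-thiazol-2-yl on an aromatic carbon. The expected step is a number 30.7 percentage points higher from compound 3 to compound 4 (beyond the scatter), resting on the earlier step of a number 37.6 percentage points higher from compound 1 to compound 2 (beyond the scatter), though compound 3 starts higher and leaves less room toward complete inhibition. Compound 4 is therefore estimated at 80%, expected to lie between 62% and 95%.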

Compound 4, percent growth inhibition at one concentration: 32.3%
Compound 4: middle estimate off by 47.7 percentage points, on the high side; the whole stated range lies above it.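

In this assay, 2-chloro-5-(trifluoromethyl)phenyl in place of 4-methylphenyl gave a number 17 percentage points lower from compound 3 to compound 4 (beyond the scatter), so the same change went the opposite way on the two cores: the same change on two cores in this assay, a number 37.6 percentage points higher (beyond the scatter) from compound 1 to compound 2 and a number 17 percentage points lower (beyond the scatter) from compound 3 to compound 4, 54.6 percentage points apart, beyond the scatter of two such steps Likewise, 1H-imidazol-2-yl in place of 1,3-thiazol-2-yl gave a number 28.1 percentage points lower from compound 2 to compound 4 (beyond the scatter), opposite to its step on the other core: the same change on two cores in this assay, a number 26.5 percentage points higher (beyond the scatter) from compound 1 to compound 3 and a number 28.1 percentage points lower (beyond the scatter) from compound 2 to compound 4, 54.6 percentage points apart, beyond the scatter of two such steps Across these four compounds, neither change can be carried over as a fixed step, but the data do not show why the two changes fail to add up.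

On these data alone, it remains open whether other groups on the amide-type nitrogen would reverse in the same way. As far as these compounds go, it is also open how an amine or a carboxylic acid in place of 1H-imidazol-2-yl would behave.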